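The source may report more compounds than this note shows. Statements on the series, on what has been measured and on what is new or still open speak of the compounds shown alone.

Compound 1, `COc1cc(/C=C/C(=O)c2cccc(O)c2)ccc1O`, was tested in an ADME assay on RAW264.7 cells (Mus musculus) for cytotoxicity, read by MTT assay, with a stated time of 24 h, tested at 2.5 ug/mL (a higher number here means a weaker effect of the compound at the concentration tested, a lower number a stronger effect), where compound 1 gives 94%. Its companion compound 2, `COc1ccc(CCC(=O)c2cccc(O)c2)c(OC)c1`, gives 88.5% in this assay; the number for compound 1 is the upper of the two, though the gap to compound 2 is within the scatter. Compound 3, `COc1ccc(/C=C/C(=O)c2cccc(O)c2)cc1OC`, differs from compound 1 by methyl in place of hydrogen on an oxygen on an aromatic ring. Going by the values given here, no step between measured compounds that differ in one place is available, so the expected step in this assay is none beyond the scatter, as the estimated a number 2 percentage points lower from compound 1 to compound 3 (within the scatter) shows. For compound 3 the expected value is 92%, between 80% and 100%.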

Compound 3, a percentage reported as activity, at one concentration (the size of the read-out at that concentration, not a potency): 91%
Beside the measured number, compound 3's estimate is 1 percentage points above it; low and high end bracket the measured number.
By their numbers in this assay, from the lowest: compounds 2, 3 and 1 (each within the scatter of the next).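

In this assay, the change from hydroxy to methoxy on an oxygen on an aromatic ring gives a number 3 percentage points lower from compound 1 to compound 3 (within the scatter), so methyl in place of hydrogen at this position leaves the read-out within the scatter. Going by these compounds alone, this is the first single-place change that can be read here, as compound 2 differs from compound 1 in more than one place. Nothing measured here speaks to the reason for this result. Whether a longer chain on this oxygen, or an amine or a carboxylic acid in place of the hydroxy, would move the read-out remains open, as does the behaviour of these compounds at other concentrations.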